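The compounds below may be only part of what the source reports. "The series", "measured", "known", "first", "only" and "open" are said of these compounds alone.

Measured so far:
compound 1, `CCCCCc1c(C(C)C)nc(C(C)C)c(CO)c1-c1ccccc1F`: 9000 nM
compound 2, `CCCCCc1c(C(C)C)nc(C(C)C)c(CO)c1-c1ccccc1O`: 500 nM

In an assay on CHO cells for inhibition of Glucagon receptor (Homo sapiens) (on this read-out lower numbers stand for stronger inhibition and higher numbers for weaker inhibition), compound 1 gives 9000 nM, the highest of the two numbers; its nearest neighbour is compound 2, which gives 500 nM. Going by the values given here, the only step measured between them, an 18-fold lower number from compound 1 to compound 2 (1.26 log units; beyond the scatter), comes from a hydroxy in place of fluoro on an aromatic carbon and is large, beyond the scatter.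

Compound 3, `CCCCCc1c(C(C)C)nc(C(C)C)c(CO)c1-c1ccc(F)c(CO)c1`, has not yet been measured. It differs from compound 1 in that (4-fluoro-3-(hydroxymethyl)phenyl in place of 2-fluorophenyl on an aromatic carbon). The entering group carries one hydrogen-bond donor and one hydrogen-bond acceptor, where the leaving 2-fluorophenyl had none; the fluorine remains, though as part of a different group.

Among the compounds with values here, only the step from compound 1 to compound 2 bears on this change, and only loosely: there a donor and acceptor entered the same ring, and the number fell by a large margin. A smaller step in the same direction is therefore expected for compound 3, namely a 3.0-fold lower number from compound 1 to compound 3 (0.48 log units; beyond the scatter). Compound 3 is estimated at 3000 nM in this assay, with a range from 800 nM to 15000 nM.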

Compound 3, half-maximal inhibitory concentration: 19000 nM
Compound 3: middle estimate off by 6.3-fold (0.80 log units), on the low side; measured number outside the range, above it.
By their numbers in this assay, from the lowest: compound 2; then compound 1; then compound 3.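

In this assay, a hydrogen-bond donor and acceptor on the group at this position do not by themselves lower the number: the change to 4-fluoro-3-(hydroxymethyl)phenyl gives a 2.1-fold higher number from compound 1 to compound 3 (0.32 log units; beyond the scatter) and so runs against the direction seen with the hydroxy of compound 2. The same group set against 2-hydroxyphenyl gives a 38-fold higher number from compound 2 to compound 3 (1.58 log units; beyond the scatter) and shows that, among these three compounds, the lower number belongs to compound 2 alone, so that carrying a donor and an acceptor does not separate compound 2 from compound 3. No measurement at hand explains why these two groups, each with a donor and an acceptor, part so widely.

Compound 3 carries its hydroxymethyl and fluoro together, so the compounds shown do not tell which of the two goes with its higher number, or whether the changed place of the fluoro matters. As far as these compounds go, it also remains open whether an amine or a methoxy group in place of the hydroxy of compound 2 would keep a number as low as that of compound 2.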